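The source may report more compounds than this note shows. Statements on the series, on what has been measured and on what is new or still open speak of the compounds shown alone.

Measured in a functional assay on RAW264.7 cells (Mus musculus) for inhibition, read by Griess assay, with stated times of 2 h and 24 h; on this read-out higher numbers stand for weaker inhibition and lower numbers for stronger inhibition:
- Compound 1 `C#CCOc1cc(O)c2c(c1)O[C@H](c1ccc(OC)c(O)c1)CC2=O` gives 20900 nM
- Compound 2 `COc1ccc([C@@H]2C/C(=N\O)c3c(O)cc(OCc4cn(Cc5ccccc5C)nn4)cc3O2)cc1O` gives 18000 nM
- Compound 3 `C=CCn1cc(COc2cc(O)c3c(c2)O[C@H](c2ccc(OC)c(O)c2)CC3=O)nn1` gives 13800 nM

Compound 2 stands with the other two, its value within the scatter of both. Compound 4 `COc1ccc([C@@H]2C/C(=N\O)c3c(O)cc(OCc4cn(CC5CC5)nn4)cc3O2)cc1O` is compound 2 with one change, cyclopropyl in place of 2-methylphenyl on a saturated chain carbon bound to an aromatic nitrogen.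

Among the measured compounds shown here, no measured step covers this exchange directly. The nearest evidence is a 1.5-fold lower number from compound 1 to compound 3 (0.18 log units; within the scatter), where 1-allyl-1H-1,2,3-triazol-4-yl replaces ethynyl, and that step stays within the scatter. Compound 3 carries allyl where compound 2 carries 2-methylbenzyl, though the two compounds also differ elsewhere. Their values, compound 3 at 13800 nM and compound 2 at 18000 nM, lie within the scatter of each other. So far, then, changes on this arm have not moved the number, and no shift beyond the scatter is expected in this assay. The estimate means a 1.2-fold lower number from compound 2 to compound 4 (0.08 log units; within the scatter). For compound 4 the estimated value is 15000 nM, in an expected range from 7000 nM to 30000 nM.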

Compound 4, half-maximal inhibitory concentration: 6320 nM
For compound 4 the middle estimate is 2.4-fold (0.38 log units) above the measured one; the whole stated range lies above it.
By their numbers in this assay, from the lowest: compound 4; then compounds 3, 2 and 1 (each within the scatter of the next).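

The exchange of 2-methylbenzyl for cyclopropylmethyl gives, in this assay, a 2.8-fold lower number from compound 2 to compound 4 (0.45 log units; beyond the scatter), the only step beyond the scatter among the compounds shown. It shows that the group on a saturated chain carbon bound to an aromatic nitrogen can move the number, which a 1.5-fold lower number from compound 1 to compound 3 (0.18 log units; within the scatter), a different change that stays within the scatter, gave no sign of. No measurement shown accounts for this shift.

This single pair changes several things at once, going from a six-membered aromatic ring of carbon only to a three-membered non-aromatic ring and from 7 heavy atoms to 3, so it cannot tell these apart. Going by these compounds, whether a plain benzyl, a cyclohexylmethyl, or an amine-bearing chain such as 2-(dimethylamino)ethyl at this place would follow compound 2 or compound 4 remains open.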